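Swapping Phenoxycarbonyl for Carboxy on a Short-Lived Compound

A few compounds are considered here, and "the series" means these few. Any claim that something is new, unique, unknown or untested is made for them only; others in the source may bear on it.

Measured in an ADME assay on a cell-free system (plasma, Homo sapiens) for metabolic stability, read by LC-MS; on this read-out lower numbers stand for a shorter-lived compound and higher numbers for a longer-lived compound
- compound 1 `NCc1ccc(C(=O)Nc2ccncc2F)cc1-c1cccc(C(=O)Oc2ccccc2)c1` gives 0.117 h
- compound 2 `CC(N)c1ccc(C(=O)Nc2ccncc2)cc1-c1ccc(F)cc1` gives > 2 h (a limit of the assay, not a number)
- compound 3 `CCCCCOC(=O)c1cccc(-c2cc(C(=O)Nc3ccncc3)ccc2CN)c1` gives 0.967 h

Compound 1 has the lowest number here. The nearest is compound 3 at 0.967 h, a gap beyond the usual scatter of repeated measurements. The third result cannot be placed exactly, since it is only a limit.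

Compound 4 (`NCc1ccc(C(=O)Nc2ccncc2F)cc1-c1cccc(C(=O)O)c1`) keeps the core of compound 1 but has hydrogen in place of phenyl on an oxygen next to a carbonyl group. This turns phenoxycarbonyl into carboxy, so compound 4 no longer carries an ester.

Within the data shown here, no measured pair shows this change directly, so the expectation rests on a loose comparison. Compound 1 and compound 3 both carry an ester and both give numbers in this assay, and neither reaches the limit. The expectation also leans on compound 2 (> 2 h), which has no ester, as is true of compound 4. These compounds differ in other places too, so the comparison is only a rough guide.

A clear rise toward a longer-lived compound is therefore expected, well beyond the scatter, with an estimated change of a 26-fold higher number from compound 1 to compound 4 (1.41 log units; beyond the scatter) in the half-life. Compound 4 is expected at 3 h (estimated range 1 h to 10 h), and the assay may well report only a limit.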

Compound 4, half-life: > 2 h
Compound 4 was reported as a limit; the forecaster's own chance of this, stated with the estimate: 75%; the middle value is on the limit's open side.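

Among these compounds, compound 1 and compound 4 are the first pair here that differ in only one place, so the effect of this change can be read directly rather than through compounds that also differ elsewhere. Putting hydrogen in place of phenyl on an oxygen next to a carbonyl group, which turns phenoxycarbonyl into carboxy and removes the ester, gives an at least 17-fold higher number from compound 1 to compound 4 (1.23 log units; beyond the scatter) in this assay, so this one position alone can move the half-life by a large amount. This step marks only the smallest possible change, and the true size stays unknown, since compound 4 reaches the end of the readable range: the limit of > 2 h in this assay, at which 2 of the 4 values shown sit.

The compounds shown leave open how far compound 4 lies past this limit, and whether the change of half-life comes from losing the phenyl ring, losing the ester, or gaining the carboxy group. A methyl ester or a primary amide at this same place would help to separate these possibilities, as either would show whether a smaller ester or a non-ester carbonyl group gives a half-life closer to that of compound 1 or of compound 4.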